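The compounds below may be only part of what the source reports. "The series", "measured", "known", "first", "only" and "open" are said of these compounds alone.

Measured compounds:
- compound 1 `Cc1ccccc1Oc1ccc(N2C[C@@H](C(F)(F)F)C[C@H]2CC(=O)O)cc1`: 73 nM
- compound 2 `Cc1ccccc1Oc1ccc(N2CCC[C@H]2CC(=O)O)cc1`: 74 nM
- compound 3 `Cc1cc(OCc2ccccc2)ccc1Oc1ccc(N2C[C@@H](C(F)(F)F)C[C@H]2CC(=O)O)cc1`: 120 nM

In a functional assay on cells for agonist activity at Free fatty acid receptor 1 (Homo sapiens), read by FLIPR and calcium flux, with a stated time of 100 s (on this read-out higher numbers stand for an effect only at larger amounts of compound and lower numbers for an effect already at smaller amounts), compound 1 gives 73 nM. Compound 2 and compound 3 give numbers that lie within the usual scatter of it: a 1.0-fold higher number from compound 1 to compound 2 (0.01 log units; within the scatter) and a 1.6-fold higher number from compound 1 to compound 3 (0.22 log units; within the scatter). Compound 1 therefore stands level with the other two; none of the three can be set apart on these numbers.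

Compound 4 `Cc1cccc(Oc2ccc(N3C[C@@H](C(F)(F)F)C[C@H]3CC(=O)O)cc2)c1C` differs from compound 1 in one place: methyl in place of hydrogen on an aromatic carbon. Going by the values given here, no measured step makes exactly this change. The nearest is the step on an aromatic carbon of the same ring, a 1.6-fold higher number from compound 1 to compound 3 (0.22 log units; within the scatter), which stayed within the scatter even with a much larger group entering; the other step, a 1.0-fold higher number from compound 1 to compound 2 (0.01 log units; within the scatter), alters a saturated ring carbon and also stayed within the scatter. Neither gives a reason to expect a shift beyond the scatter in this assay from a single added methyl.

Compound 4 is accordingly expected to give about 75 nM, with a range from 30 nM to 190 nM. This estimate means a step of a 1.0-fold higher number from compound 1 to compound 4 (0.01 log units; within the scatter), which is expected to stay within the scatter.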

Compound 4, half-maximal effective concentration: 110 nM
Beside the measured number, compound 4's estimate is 1.5-fold (0.17 log units) below it, and the stated range covers the measured number.
By their numbers in this assay, from the lowest: compounds 1, 2, 4 and 3 (each within the scatter of the next).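

Going from 2-methylphenoxy to 2,3-dimethylphenoxy in this assay gives a step that stays within the usual scatter (a 1.5-fold higher number from compound 1 to compound 4 (0.18 log units; within the scatter)), so a single methyl on this aromatic carbon, ortho to a methyl group, leaves the read-out where it was. With the step to the much larger benzyloxy group on the same ring (a 1.6-fold higher number from compound 1 to compound 3 (0.22 log units; within the scatter)), this makes two additions to this ring, at different carbons, that both stay within the scatter. No measurement on hand offers an explanation for this result.

On these data alone, it remains open whether a fluorine, a methoxy group, a carboxylic acid or a longer chain such as ethyl at this same aromatic carbon would also stay within the scatter. Also open, as far as these compounds go, is whether the added methyl would behave the same way on the core of compound 2, which lacks the trifluoromethyl group.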